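This account rests on a few compounds, and the source may have more. Where it says the series, first, only, none or still open, it means among the compounds named here.

Measured in a functional assay on HeLa cells (Homo sapiens) for cytotoxicity, read by MTT assay; on this read-out lower numbers stand for stronger inhibition and higher numbers for weaker inhibition:
compound 1, `CC(C)[C@H](NC(=S)Nc1cc(C(F)(F)F)cc(C(F)(F)F)c1)c1nc2ccccc2[nH]1`: 28900 nM
compound 2, `C[C@H](NC(=S)Nc1cc(C(F)(F)F)cc(C(F)(F)F)c1)c1nc2ccccc2[nH]1`: 133000 nM

Compound 2 stands at the higher of the two numbers, meaning the weaker of the two in this assay. For the measured compounds named here, the only step measured so far, a 4.6-fold higher number from compound 1 to compound 2 (0.66 log units; beyond the scatter), came from a change of group size at the carbon next to the thiourea nitrogen, not from any change of handedness at that carbon.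

Compound 3, `C[C@@H](NC(=S)Nc1cc(C(F)(F)F)cc(C(F)(F)F)c1)c1nc2ccccc2[nH]1`, is the next compound to be tested. Against compound 2 the difference is this: the two compounds have the same atoms and bonds and differ only in configuration as drawn: 1 of 1 stereo elements differ; a stereocentre at a saturated chain carbon is drawn S in compound 2 and R in compound 3. In other words the two compounds are mirror images at that one carbon and nothing else changes.

Going by the values given here, no measured step bears on a change of configuration, so the one step known here gives no guide to direction or size. Mirror-image pairs can sit close together or far apart in this assay, and nothing in the data chooses between those outcomes. The estimate therefore rests on compound 2 itself: compound 3 is expected at 133000 nM, within a wide range from 30000 nM to 500000 nM, which amounts to an expected step of no change at the digits printed from compound 2 to compound 3 (within the scatter).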

Compound 3, half-maximal inhibitory concentration: 16100 nM
The estimate for compound 3 lay 8.3-fold (0.92 log units) above the measured number, outside the stated range (below it).
By their numbers in this assay, from the lowest: compounds 3 and 1 (each within the scatter of the next); then compound 2.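

In this assay, the earlier step spoke only to the size of the group on this saturated chain carbon, whereas the new comparison gives an 8.3-fold lower number from compound 2 to compound 3 (0.92 log units; beyond the scatter), so the handedness of this same carbon matters by itself. With methyl on this carbon, the form drawn R is the stronger member of the mirror-image pair, which means that the two forms cannot be treated as interchangeable in this series. The shift can be assigned to configuration alone, because no atom or bond separates the pair and only one stereo element is in play: the fact that compounds 2 and 3 differ only in the configuration as drawn

The compounds shown leave open whether the R form would also be the stronger one with isopropyl on this carbon, as the isopropyl compound appears here only as compound 1, in a single configuration. They also leave open whether the preference for one hand would persist, grow or vanish with a longer chain such as n-butyl or with a benzyl group at this position.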